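Methoxy for methyl: a small change to compound 2

The compounds below may be only part of what the source reports. "The series", "measured", "known", "first", "only" and "open" are said of these compounds alone.

Of the compounds shown here, two sharing one core have been measured in an assay on CHO cells for displacement of a labelled ligand from muscarinic acetylcholine receptor M5 (Homo sapiens), read by scintillation counting, with a stated time of 2 h; a lower number here means a stronger inhibitor, a higher number a weaker inhibitor. Compound 1 `O=C(OCCc1ccc(Cl)c(Cl)c1)N(c1ccccc1)C1CN2CCC1CC2` gives 80 nM. Within the data shown here, compound 2 `Cc1ccc(COC(=O)N(c2ccccc2)C2CN3CCC2CC3)cc1F` gives 30 nM, the lower of the two numbers, and the only measured step, a 2.7-fold lower number from compound 1 to compound 2 (0.43 log units; beyond the scatter), is beyond the scatter, so compound 2 is the stronger binder of the pair. Compound 3 `COc1ccc(COC(=O)N(c2ccccc2)C2CN3CCC2CC3)cc1F` has not been measured yet. It differs from compound 2 in one place: methoxy in place of methyl on an aromatic carbon. Among the measured compounds shown here, no measured step exchanges a methyl for a methoxy group, so the one step known bears on this change only loosely: it alters a different part of the molecule and shows that a change there moved the number by a modest amount. With no closer comparison available, the step expected in this assay is small, in either direction, and most likely not beyond the scatter. Compound 3 is therefore estimated to give about 40 nM, within a range from 15 nM to 120 nM. That estimate means an expected step of a 1.3-fold higher number from compound 2 to compound 3 (0.12 log units; within the scatter).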

Compound 3, inhibition constant: 40 nM
Compound 3: the middle estimate sits on the measured number at the digits printed; the range from low to high includes it.
By their numbers in this assay, from the lowest: compounds 2, 3 and 1 (each within the scatter of the next, the first and the last beyond it).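

In this assay, exchanging methyl for methoxy on the aromatic carbon para to a large group and ortho to a fluoro group gives a 1.3-fold higher number from compound 2 to compound 3 (0.12 log units; within the scatter), so adding one oxygen and one hydrogen-bond acceptor at this position has no effect that can be told from the usual scatter. The wider change, with 3-fluoro-4-methoxyphenyl in place of 3,4-dichlorobenzyl, gives a 2.0-fold lower number from compound 1 to compound 3 (0.30 log units; within the scatter), which also lies within the scatter, so compound 3 cannot be separated from either compound 1 or compound 2, even though those two can be separated from each other. No separate measurement is available to explain why the methyl-to-methoxy exchange shows so little effect.

The compounds shown leave open whether this position would accept groups of a different kind, such as an amine or a carboxylic acid, as readily as it accepts methyl and methoxy. They also leave open whether a longer chain, such as propoxy, would keep the number in the same range, and whether the result for methoxy would hold without the neighbouring fluoro group.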